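A few compounds are considered here, and "the series" means these few. Any claim that something is new, unique, unknown or untested is made for them only; others in the source may bear on it.

Compound 1 `NCCCCCCOc1ccc2c(=O)c(-c3ccc(O)cc3)coc2c1` stands lowest of the three numbers in hand. In an assay (Cricetulus griseus) for inhibition of aldehyde dehydrogenase, mitochondrial (Homo sapiens) (on this read-out higher numbers stand for weaker inhibition and lower numbers for stronger inhibition), compound 1 gives 100 nM. Compound 2 `O=c1c(-c2ccc(O)cc2)coc2cc(OCCCCCCCCCCCCO)ccc12` gives 1700 nM in this assay, and compound 3 `CCCCC(Oc1ccc2c(=O)c(-c3ccc(O)cc3)coc2c1)C(=O)OCC` gives 4500 nM. Among the compounds with values here, the one step between neighbours that differ in a single place is a 17-fold higher number from compound 1 to compound 2 (1.23 log units; beyond the scatter), a 6-hydroxyhexyl in place of amino on a saturated chain carbon, six bonds along the chain from an oxygen on an aromatic ring.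

Compound 4 `O=C(O)CCCCCCOc1ccc2c(=O)c(-c3ccc(O)cc3)coc2c1` has not yet been measured in this assay. It differs from compound 1 by carboxy in place of amino on a saturated chain carbon, six bonds along the chain from an oxygen on an aromatic ring. Within the data shown here, only the step to compound 2 bears on this change, since it alters the same saturated chain carbon six bonds along the chain from the oxygen on the aromatic ring, and there the replacement of the amino was followed by a large loss. Compound 4 keeps the chain length of compound 1 and only exchanges the terminal group, so a smaller loss than that seen for compound 2 is expected, though still one that may exceed the scatter; an expected step of a 4.0-fold higher number from compound 1 to compound 4 (0.60 log units; beyond the scatter) follows from a 17-fold higher number from compound 1 to compound 2 (1.23 log units; beyond the scatter). Compound 4 is therefore estimated at 400 nM in this assay, with a range from 100 nM to 1600 nM.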

Compound 4, half-maximal inhibitory concentration: 50 nM
Beside the measured number, compound 4's estimate is 8.0-fold (0.90 log units) above it, and the stated range ends above it.
By their numbers in this assay, from the lowest: compounds 4 and 1 (each within the scatter of the next); then compound 2; then compound 3.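

In this assay, carboxy in place of amino on the saturated chain carbon, six bonds along the chain from the oxygen on the aromatic ring, gives a 2.0-fold lower number from compound 1 to compound 4 (0.30 log units; within the scatter), so this read-out does not tell the two terminal groups apart. The earlier compounds shown here showed only a large loss on replacing the amino, and this result shows that such a loss does not follow every replacement there: the amino can give way to carboxy with the number staying within the scatter. The same place also separates the two other groups, with a 34-fold lower number from compound 2 to compound 4 (1.53 log units; beyond the scatter), so the large step belongs to the 6-hydroxyhexyl rather than to the loss of the amino as such, while nothing given here accounts for either step.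

The compounds shown leave open whether the long chain of compound 2 or its terminal hydroxy goes with the higher number, which a hydroxy on the shorter chain of compound 1 would help to separate. They also leave open how a shorter or longer chain ending in an amine or a carboxylic acid would read, and whether an ester or amide at the chain end would stay level with compound 1 and compound 4.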